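Three Acylamines at the Cytotoxicity Limit; a Fourth Expected

The source may report more compounds than this note shows. Statements on the series, on what has been measured and on what is new or still open speak of the compounds shown alone.

Compound 1, `Cc1ccc(S(=O)(=O)N[C@@H](CC(=O)NC(C)(C)C)C(=O)NCCNC(=O)c2cc(Cl)ccn2)cc1`: > 11100 nM
Compound 2, `Cc1ccc(S(=O)(=O)N[C@@H](CC(=O)NC(C)(C)C)C(=O)NCCNC(=O)c2ccccc2)cc1`: > 11100 nM
Compound 3, `Cc1ccc(S(=O)(=O)N[C@@H](CC(=O)NC(C)(C)C)C(=O)NCCNC(=O)c2c(O)cccc2F)cc1`: > 11100 nM

The three measured compounds share a core and differ only in the group on the carbonyl carbon of the terminal amide. In an ADME assay on Karpas-1106P cells (Homo sapiens) for cytotoxicity (on this read-out higher numbers stand for an effect only at larger amounts of compound and lower numbers for an effect already at smaller amounts), compound 1 gives > 11100 nM, which is a limit of the assay and not a number. Compound 2 likewise reaches only a limit in this assay, > 11100 nM. Compound 3 also sits at a limit in this assay, > 11100 nM. All three therefore stand at the limit of > 11100 nM in this assay, at which 3 of the 3 values shown sit, so compound 1 cannot be placed above or below its neighbours.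

Among the measured compounds shown here, the steps that bear on the new compound both start from compound 1: a step that the two limits leave unreadable from compound 1 to compound 2, and a step that the two limits leave unreadable from compound 1 to compound 3. Neither has a readable size. The change to compound 4, `Cc1ccc(S(=O)(=O)N[C@@H](CC(=O)NC(C)(C)C)C(=O)NCCNC(=O)c2ccc(F)c(F)c2)cc1`, is 3,4-difluorophenyl in place of 4-chloropyridin-2-yl on a carbonyl carbon.

Since every exchange of this group so far has left the read-out at the limit, no step beyond the scatter is expected in this assay from compound 1 to compound 4; the expected step is a step that the limit leaves unreadable from compound 1 to compound 4. Compound 4 is thus estimated at 20000 nM, within the range 8000 nM to 50000 nM, most likely again reported only as a limit.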

Compound 4, half-maximal effective concentration: > 11100 nM
Compound 4 was reported as a limit; the forecaster's own chance of this, stated with the estimate: 85%; the middle value lies beyond the limit too.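

In this assay compound 4 gives > 11100 nM, which is a limit of the assay and not a number. Among the compounds shown here, no step between compound 4 and compound 1, compound 2 or compound 3 can be read: the limit of > 11100 nM in this assay, at which 4 of the 4 values shown sit. The compounds shown leave open where the true values of all four lie and whether any group on this carbonyl carbon would give a measurable value.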